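Successive N-Methylation in a Sigma-1 Binding Series

The source may hold more compounds than are shown below. What is called first, only, known or untested is meant among the compounds shown, and "the series" means these compounds.

All three measured compounds were tested in an assay for displacement of a labelled ligand from Sigma non-opioid intracellular receptor 1 (Cavia porcellus), read by scintillation counting; a lower number here means a stronger inhibitor, a higher number a weaker inhibitor.
Compound 1, `NCC[C@@H]1CCO[C@H](c2ccccc2)O1`, gives 165 nM.
Compound 2, `NCCC[C@@H]1CCO[C@H](c2ccccc2)O1`, gives 167 nM.
Compound 3, `CNCCC[C@@H]1CCO[C@H](c2ccccc2)O1`, gives 327 nM.

Compound 3 is not separated from the other two: the steps of a 2.0-fold higher number from compound 1 to compound 3 (0.30 log units; within the scatter) and a 2.0-fold higher number from compound 2 to compound 3 (0.29 log units; within the scatter) both lie within the scatter, as does a 1.0-fold higher number from compound 1 to compound 2 (0.01 log units; within the scatter). Compound 4, `CN(C)CCC[C@@H]1CCO[C@H](c2ccccc2)O1`, differs from compound 3 by methyl in place of hydrogen on an amine nitrogen. The step that bears directly on this change is a 2.0-fold higher number from compound 2 to compound 3 (0.29 log units; within the scatter), the same kind of change one stage earlier, which stayed within the scatter. Compound 4 is therefore expected to show a 1.4-fold higher number from compound 3 to compound 4 (0.14 log units; within the scatter), a small rise in the number at most, possibly none beyond the scatter. The estimate for compound 4 in this assay is 450 nM, with a range from 180 nM to 1200 nM.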

Compound 4, inhibition constant: 1220 nM
Compound 4: middle estimate off by 2.7-fold (0.43 log units), on the low side, outside the stated range (above it).
By their numbers in this assay, from the lowest: compounds 1, 2 and 3 (each within the scatter of the next); then compound 4.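

In this assay, the second methyl on the amine nitrogen matters where the first did not: a 3.7-fold higher number from compound 3 to compound 4 (0.57 log units; beyond the scatter) lies beyond the scatter, whereas the first methyl's step stayed within it, so the two methyls do not contribute equally. The dimethylamino compound also separates from both primary amines, with a 7.3-fold higher number from compound 2 to compound 4 (0.86 log units; beyond the scatter) and a 7.4-fold higher number from compound 1 to compound 4 (0.87 log units; beyond the scatter), each beyond the scatter. Nothing measured here explains this rise.

Going by these compounds, it remains open whether an ethyl group or a pyrrolidine ring on this nitrogen would behave like dimethylamino. On these data alone, it is also open whether dimethylamino on the chain of compound 1 would give a similar step.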